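Series notes: pyridin-4-yl for propanoyl on the shared core

The source may report more compounds than this note shows. Statements on the series, on what has been measured and on what is new or still open speak of the compounds shown alone.

Going by the values given here, compound 1 `CCC(=O)c1ccc2c(c1)C(n1ccccc1=O)=CC(C)(C)O2` stands highest of the two numbers measured so far. In a functional assay (aorta) with Rattus norvegicus as the target (on this read-out higher numbers stand for higher potency (the scale is a negative logarithm) and lower numbers for lower potency), compound 1 gives 6.63. Its nearest neighbour is compound 2 `CC1(C)C=C(n2ccccc2=O)c2cc(OCC(=O)c3ccc(F)cc3)ccc2O1`, which in this assay gives 4.63, a lower number, and the gap between the two lies beyond the scatter. Among the compounds with values here, no pair of measured compounds differs in only one place, so no single step can be read from the measured set.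

Compound 3 `CC1(C)C=C(n2ccccc2=O)c2cc(-c3ccncc3)ccc2O1` is the next compound to be measured in this assay. Relative to compound 1 it shows the following change: pyridin-4-yl in place of propanoyl on an aromatic carbon. Within the data shown here, with no comparable step on record, the expectation is a modest loss rather than none, with the step from a number 0.63 log units lower from compound 1 to compound 3 (beyond the scatter) expected to fall short of the scatter in no certain way. Compound 3 is estimated at 6 in this assay, with a range from 5 to 7.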

Compound 3, logarithm of the reciprocal of the active concentration, log(1/C): 6.68
Beside the measured number, compound 3's estimate is 0.68 log units below it; the measured number falls inside the stated range.
By their numbers in this assay, from the lowest: compound 2; then compounds 1 and 3 (each within the scatter of the next).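

In this assay the exchange of propanoyl for pyridin-4-yl on the aromatic carbon gives a number 0.05 log units higher from compound 1 to compound 3 (within the scatter) and so leaves the number unchanged within the scatter. This position therefore accepts a six-membered aromatic ring with one hetero atom as readily as an open chain bearing a carbonyl, so on this pair neither the ring nor the chain is required for a number at this level. No measurement on hand accounts for the match between these two groups.

On these data alone, whether the ring nitrogen matters remains open, since a plain phenyl or a pyridin-3-yl ring at this position would be needed to show it. Equally open, as far as these compounds go, is how this position responds to an amine, a carboxylic acid or a longer acyl chain.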